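Chloro in place of hydrogen on compound 1

A few compounds are considered here, and "the series" means these few. Any claim that something is new, unique, unknown or untested is made for them only; others in the source may bear on it.

Of the compounds shown here, three sharing one core have been tested in a functional assay, with a stated time of 6 min; on this read-out lower numbers stand for stronger inhibition and higher numbers for weaker inhibition. Compound 1 `S=c1oc(-c2ccc3c(c2)OCCO3)nn1CNc1ccccc1` gives 5140 nM. Compound 2 `Fc1ccccc1NCn1nc(-c2ccc3c(c2)OCCO3)oc1=S`, which carries a fluoro in place of a hydrogen, gives 6390 nM, and compound 3 `S=c1oc(-c2ccc3c(c2)OCCO3)nn1CNc1ccccc1Cl`, which carries a chloro in place of a hydrogen, gives 7230 nM. Compound 1 has the lowest of the three numbers, yet the steps of a 1.2-fold higher number from compound 1 to compound 2 (0.09 log units; within the scatter) and a 1.4-fold higher number from compound 1 to compound 3 (0.15 log units; within the scatter) are both within the scatter, as is a 1.1-fold higher number from compound 2 to compound 3 (0.05 log units; within the scatter), so the three compounds cannot be told apart on this read-out.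

Compound 4 `S=c1oc(-c2ccc3c(c2)OCCO3)nn1CNc1cccc(Cl)c1` is not yet measured. It differs from compound 1 by chloro in place of hydrogen on an aromatic carbon. For the measured compounds named here, the steps that bear on this change are the two in which a halogen entered the same ring of compound 1, namely the step to compound 2 and the step to compound 3; both left the number essentially where it was. On that basis no step beyond the scatter is expected for compound 4, and the change expected from compound 1 is a 1.1-fold higher number from compound 1 to compound 4 (0.03 log units; within the scatter). Compound 4 is therefore estimated at 5500 nM, with a range from 2500 nM to 12000 nM.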

Compound 4, half-maximal inhibitory concentration: 6220 nM
The estimate for compound 4 lay 1.1-fold (0.05 log units) below the measured number, within the range that was stated.
By their numbers in this assay, from the lowest: compounds 1, 4, 2 and 3 (each within the scatter of the next).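

Chloro at this new place on the ring, meta to a large group, gives a 1.2-fold higher number from compound 1 to compound 4 (0.08 log units; within the scatter) in this assay, so a second placement of a halogen also leaves the number within the scatter of compound 1. Moving the chloro, with 3-chlorophenyl in place of 2-chlorophenyl, gives a 1.2-fold lower number from compound 3 to compound 4 (0.07 log units; within the scatter) and 3-chlorophenyl in place of 2-fluorophenyl gives a 1.0-fold lower number from compound 2 to compound 4 (0.01 log units; within the scatter); both steps are within the scatter, so for the first time this read-out can be seen not to separate these two placements of a chloro on this ring. Nothing at hand explains why the four numbers lie so close together.

Every compound shown carries only hydrogen or a single halogen on this ring, so it remains open whether a methoxy, an amine or a carboxylic acid there would move the number beyond the scatter. Going by these compounds, it also remains open whether a longer chain between the shared core and the amine nitrogen would change the number by more than the halogens have.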